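A few compounds are considered here, and "the series" means these few. Any claim that something is new, unique, unknown or untested is made for them only; others in the source may bear on it.

Measured so far in an ADME assay on microsomes from liver (Mus musculus, strain CD-1) for metabolic stability, read by LC-MS, tested at 2 uM; on this read-out higher numbers stand for a longer-lived compound and lower numbers for a shorter-lived compound:
compound 1 `Cn1ccc2ccc(-c3cc(Nc4ccccc4S(=O)(=O)Nc4cncnc4)cc4nccnc34)cc21` at 0.683 h;
compound 2 `CN1CCC(NS(=O)(=O)c2ccccc2Nc2cc(-c3ccc4ccn(C)c4c3)c3nccnc3c2)C1` at 0.667 h;
compound 3 `CC(=O)N1CCC(NC(=O)c2ccncc2Nc2cc(-c3ccc4ccn(C)c4c3)c3nccnc3c2)CC1` at 0.117 h.

Compound 3 stands lowest of the three, and its distance from compound 2 as well as from compound 1 lies beyond the usual scatter. Compound 4 `CN1CCC(N(C)C(=O)c2ccncc2Nc2cc(-c3ccc4ccn(C)c4c3)c3nccnc3c2)C1` has not yet been measured. It differs from compound 3 in one place: methyl(1-methylpyrrolidin-3-yl)amino in place of (1-acetylpiperidin-4-yl)amino on a carbonyl carbon. Going by the values given here, the only measured step, a 1.0-fold lower number from compound 1 to compound 2 (0.01 log units; within the scatter), exchanges pyrimidin-5-yl for 1-methylpyrrolidin-3-yl on a sulfonamide nitrogen and lay within the scatter; it bears only loosely on the present change, as compound 3 and compound 4 carry their amine on a carbonyl carbon rather than on a sulfonamide. Compound 2, which already carries a 1-methylpyrrolidin-3-yl, gives 0.667 h, a number well above that of compound 3. Among the compounds with values here, no measured pair covers the change from (1-acetylpiperidin-4-yl)amino to methyl(1-methylpyrrolidin-3-yl)amino. For compound 4 a modest rise is therefore expected, a 2.1-fold higher number from compound 3 to compound 4 (0.33 log units; beyond the scatter), with a broad range. For compound 4 in this assay the estimated value is 0.25 h, between 0.08 h and 0.8 h.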

Compound 4, half-life: > 1 h
Compound 4: only a limit was reported (the forecaster's own chance of this, stated with the estimate: 5%); middle value at least 4.0-fold (0.60 log units) away from the limit.
By their numbers in this assay, from the lowest: compound 3; then compounds 2 and 1 (each within the scatter of the next). At a limit, above all of these: compound 4.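

On the carbonyl carbon whose other neighbour is an aromatic carbon, methyl(1-methylpyrrolidin-3-yl)amino in place of (1-acetylpiperidin-4-yl)amino gives an at least 8.5-fold higher number from compound 3 to compound 4 (0.93 log units; beyond the scatter) in this assay. Compound 4 is reported only as a limit, so this step has a floor and no measured size: the limit of > 1 h in this assay, at which 1 of the 4 values shown sits. The other step shown, on a sulfonamide nitrogen, lay within the scatter, so this amine exchange on a carbonyl carbon is the only change here that moves the half-life beyond it.

The exchange alters the ring size, the acetyl group and the amide hydrogen together, and the compounds shown do not separate these parts. Going by these compounds, how a morpholine or a plain dimethylamino group on the same carbonyl carbon would fare also stays open.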